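Ethyl for hydroxy on a triazole side chain

The compounds below may be only part of what the source reports. "The series", "measured", "known", "first", "only" and "open" are said of these compounds alone.

Measured so far in a functional assay on HepG2 cells (Homo sapiens) for antiproliferative activity, read by MTT assay, with a stated time of 72 h; on this read-out lower numbers stand for stronger inhibition and higher numbers for weaker inhibition:
Compound 1 `O=C1O[C@H]([C@@H](O)Cn2cc(CCO)nn2)C(OCc2ccccc2)=C1OCc1ccccc1` gives 68100 nM in this assay.
Compound 2 `O=C1O/C(=C\Cn2cc(-c3ccc(Br)cc3)nn2)C(OCc2ccccc2)=C1OCc1ccccc1` reaches only the assay limit of > 100000 nM in this assay.
Compound 3 `O=C1O/C(=C\Cn2cc(-c3cccc(O)c3)nn2)C(OCc2ccccc2)=C1OCc1ccccc1` gives 61700 nM in this assay.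

Compound 1 holds the highest of the two numbers shown, though its gap to compound 3 lies within the scatter, while compound 2 sits at the limit (the limit of > 100000 nM in this assay, at which 1 of the 3 values shown sits). Within the data shown here, the only measured step, an at least 1.6-fold lower number from compound 2 to compound 3 (0.20 log units; that floor lies within the scatter), concerns the 3-hydroxyphenyl and 4-bromophenyl groups, not the chain. Compound 4 `CCCCc1cn(C[C@H](O)[C@H]2OC(=O)C(OCc3ccccc3)=C2OCc2ccccc2)nn1` differs from compound 1 by ethyl in place of hydroxy on a saturated chain carbon, two bonds along the chain from an aromatic carbon. Among the measured compounds shown here, no measured step covers this change, so no movement beyond the scatter is expected. Compound 4 is estimated at 55000 nM (from 18000 nM to 160000 nM). The expected step is a 1.2-fold lower number from compound 1 to compound 4 (0.09 log units; within the scatter).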

Compound 4, half-maximal inhibitory concentration: 32800 nM
Estimate against measurement, compound 4: 1.7-fold (0.22 log units) above, within the range that was stated.
By their numbers in this assay, from the lowest: compounds 4, 3 and 1 (each within the scatter of the next, the first and the last beyond it). At a limit, above all of these: compound 2.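

Ethyl in place of hydroxy on a saturated chain carbon, two bonds along the chain from an aromatic carbon, gives a 2.1-fold lower number from compound 1 to compound 4 (0.32 log units; beyond the scatter) in this assay. Among these compounds, this is the first measured step at this position, and it shows that the number responds to a change in this chain as well as being open to change at the aromatic groups. Nothing at hand bears on why the number moved.

The compounds shown do not separate the loss of hydroxy from the gain in chain length. Going by these compounds, how an amine or a carboxylic acid at the chain end, or a longer chain such as hexyl, would read stays open.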